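Swapping the aryl arm on the sulfur-linked chain

The compounds below may be only part of what the source reports. "The series", "measured", "known", "first", "only" and "open" are said of these compounds alone.

Compound 1, `Cc1cc(Nc2cc(-c3ccccc3)[nH]n2)n2nc(SCc3c(Cl)cccc3Cl)nc2n1`, gives 39600 nM in an ADME assay on GES1 cells (Homo sapiens) for inhibition, read by MTT assay, with a stated time of 72 h; on this read-out higher numbers stand for weaker inhibition and lower numbers for stronger inhibition.
Compound 2, `Cc1cc(Nc2cc(-c3ccccc3)[nH]n2)n2nc(SCC3CCCCC3)nc2n1`, reaches only > 50000 nM in this assay, which is a limit of the assay rather than a number.
Compound 3, `Cc1cc(Nc2cc(-c3ccccc3)[nH]n2)n2nc(SCc3ccccc3Br)nc2n1`, gives 41100 nM in this assay.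

Among the two numbers shown, compound 1 stands at the lowest, and the step of a 1.0-fold higher number from compound 1 to compound 3 (0.02 log units; within the scatter) lies within the scatter, so the two cannot be put in order. Compound 2 sits at the limit of > 50000 nM in this assay, at which 1 of the 3 values shown sits.

Compound 4, `Cc1cc(Nc2cc(-c3ccccc3)[nH]n2)n2nc(SCc3cccc4ccccc34)nc2n1`, has not yet been measured. It differs from compound 1 in one place: naphthalen-1-yl in place of 2,6-dichlorophenyl on a saturated chain carbon bound to a sulfur. The measured steps at that same place bear on it: an at least 1.2-fold higher number from compound 1 to compound 2 (0.10 log units; that floor lies within the scatter) and a 1.0-fold higher number from compound 1 to compound 3 (0.02 log units; within the scatter). Neither replacement of the 2,6-dichlorophenyl group moved the number beyond the scatter, and one of them ended at a limit. The expected step for compound 4 is therefore a 1.1-fold higher number from compound 1 to compound 4 (0.03 log units; within the scatter), no step beyond the scatter in this assay. Compound 4 is estimated at 42000 nM, with a range from 20000 nM to 90000 nM, and a fair chance that only a limit is returned.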

Compound 4, half-maximal inhibitory concentration: 36300 nM
The estimate for compound 4 lay 1.2-fold (0.06 log units) above the measured number; measured number inside the range.
By their numbers in this assay, from the lowest: compounds 4, 1 and 3 (each within the scatter of the next). At a limit, above all of these: compound 2.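

Naphthalen-1-yl carries no halogen, yet in this assay placing it on the saturated chain carbon bound to a sulfur leaves the number within the scatter of the halogen-bearing aryl groups (a 1.1-fold lower number from compound 1 to compound 4 (0.04 log units; within the scatter); a 1.1-fold lower number from compound 3 to compound 4 (0.05 log units; within the scatter)), so among compounds 1, 3 and 4 a halogen on the ring is not needed for a number of this size. The comparison with cyclohexyl still separates nothing, since its floor lies within the scatter (an at least 1.3-fold lower number from compound 2 to compound 4 (0.13 log units; that floor lies within the scatter)). Compound 2 remains a limit of the assay rather than a number: the limit of > 50000 nM in this assay, at which 1 of the 4 values shown sits.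

Still open, from the compounds shown here alone, is whether a different kind of group on this chain, such as an amine or a carboxylic acid, would move the number beyond the scatter. A longer chain between the sulfur and the ring leaves the same question open.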